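Alpha-methylene lactone carbinols: side-chain extension from compound 2

The source may hold more compounds than are shown below. What is called first, only, known or untested is meant among the compounds shown, and "the series" means these compounds.

Two carbinol-bearing alpha-methylene lactones have been measured so far. Compound 1 `C=C1C[C@](C)(CO)OC1=O` carries the hydroxymethyl on a quaternary ring carbon; in a functional assay on HL-60 cells (Homo sapiens) for cytotoxicity (on this read-out higher numbers stand for weaker inhibition and lower numbers for stronger inhibition), compound 1 gives 51300 nM. Compound 2 `C=C1C[C@H]([C@H](C)O)OC1=O` moves the hydroxyl onto a one-carbon branch of the side chain, and in this assay compound 2 gives 46800 nM. Compound 2 thus holds the lowest of the two numbers, but compound 1 stands within the scatter of it, so the two values are indistinguishable on this read-out.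

Compound 3 `C=C1C[C@H]([C@@H](O)CCC)OC1=O` is the next member. Relative to compound 2 the change is ethyl in place of hydrogen on a saturated chain carbon, two bonds along the chain from an oxygen on a saturated carbon and a saturated ring carbon. No measured step of this kind exists in the series, so nothing shown supports a directional call beyond the scatter. The expected step from compound 2 to compound 3 is therefore a 1.6-fold lower number from compound 2 to compound 3 (0.19 log units; within the scatter), small and leaning, if anywhere, toward a lower number. For compound 3 the estimate in this assay is 30000 nM, with a range from 12000 nM to 75000 nM.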

Compound 3, half-maximal inhibitory concentration: 52600 nM
For compound 3 the middle estimate is 1.8-fold (0.24 log units) below the measured one; low and high end bracket the measured number.
By their numbers in this assay, from the lowest: compounds 2, 1 and 3 (each within the scatter of the next).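

In this assay, among these compounds, the first measured step on this side chain, ethyl in place of hydrogen on a saturated chain carbon, two bonds along the chain from an oxygen on a saturated carbon and a saturated ring carbon, reads a 1.1-fold higher number from compound 2 to compound 3 (0.05 log units; within the scatter). Read one bond further out as methyl to propyl, this difference of 2 carbon heavy atoms gives no separation from the scatter, so this position tolerates the ethyl without a readable shift on this read-out, and the step gives the series its first direct reading at this place. No measurement in hand bears on the reason for this result.

The compounds shown leave open whether a longer chain or a branched chain such as isopropyl at this carbon would move the number beyond the scatter, since a single step cannot define a trend along the chain. They also leave open whether an amine or a carboxylic acid in place of the hydroxyl on the side chain would give a readable step in this assay.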